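The compounds below may be only part of what the source reports. "The series", "measured", "known", "first", "only" and "open" are said of these compounds alone.

Of the compounds shown here, three that share one core have been measured in a functional assay on NCI-H522 cells (Homo sapiens) for inhibition, read by sulforhodamine B assay, with a stated time of 48 h; on this read-out higher numbers stand for weaker inhibition of growth and lower numbers for stronger inhibition of growth. Compound 1, with the structure `Nc1cc(N)c2nc(-c3ccccc3)c(NCc3ccc(Cl)c(Cl)c3)nc2c1`, gives 2040 nM in this assay, the lowest of the three numbers. Compound 2, with the structure `CCOC(=O)[C@H](CCC(=O)O)NC(=O)c1ccc(Sc2nc3cc(N)cc(N)c3nc2-c2ccccc2)cc1`, gives 21400 nM in this assay, and compound 3, with the structure `Nc1cc(N)c2nc(-c3ccccc3)c(Oc3ccc(F)cc3)nc2c1`, gives 64600 nM in this assay, so compound 1 stands apart from both, with the gap to compound 2 and the still larger gap to compound 3 each beyond the scatter.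

The piece now turns to compound 4, with the structure `COc1ccc(CNc2nc3cc(N)cc(N)c3nc2-c2ccccc2)cc1`, not yet measured in this assay. Compound 4 differs from compound 1 in one place: 4-methoxyphenyl in place of 3,4-dichlorophenyl on a saturated chain carbon bound to a nitrogen on an aromatic ring. For the measured compounds named here, no measured pair shows this change, so the data give no step to lean on. The change is expected to give a step of moderate size from compound 1 to compound 4 in this assay, toward weaker growth inhibition, somewhat beyond the scatter, and this expected step is a 2.7-fold higher number from compound 1 to compound 4 (0.43 log units; beyond the scatter). Compound 4 is therefore estimated to give 5500 nM in this assay, within a range from 1500 nM to 20000 nM.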

Compound 4, concentration for 50% growth inhibition: 10000 nM
Compound 4: the middle estimate sits 1.8-fold (0.26 log units) below what was measured; the measured number falls inside the stated range.
By their numbers in this assay, from the lowest: compound 1; then compound 4; then compound 2; then compound 3.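

The place on a saturated chain carbon bound to a nitrogen on an aromatic ring now has its first measured change: in this assay, going from 3,4-dichlorobenzyl to 4-methoxybenzyl gives a 4.9-fold higher number from compound 1 to compound 4 (0.69 log units; beyond the scatter), a modest step toward weaker growth inhibition. Both groups carry one six-membered aromatic ring of carbon only and the same number of heavy atoms, so the outcome at this place depends on what that ring carries, not only on a ring being present. No measured property bears on why this step arises.

From the compounds shown here alone, a single pair changes both the ring's substituents at once, so it remains open whether losing the chlorines or gaining the methoxy group accounts for the step. An unsubstituted benzyl group or a 4-chlorobenzyl group at this place would help separate the two.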